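The source may report more compounds than this note shows. Statements on the series, on what has been measured and on what is new or still open speak of the compounds shown alone.

Compound 1, `COc1ccc(/C=c2/sc3n(c2=O)C(c2ccc(Br)cc2)C(C(=O)Nc2ccc(F)cc2)=C(C)N=3)cc1OC`: 8%
Compound 2, `CC1=C(C(=O)Nc2ccc(F)cc2)C(c2ccc([N+](=O)[O-])cc2)n2c(s/c(=C/c3ccc(Cl)cc3Cl)c2=O)=N1`: 17%
Compound 3, `CC1=C(C(=O)Nc2ccc(F)cc2)C(c2ccc(Cl)cc2)n2c(s/c(=C/c3ccc(Br)cc3)c2=O)=N1`: 35%

These three compounds, built on one shared core, were tested in a functional assay on the whole organism (strain albino) for inhibition, with Rattus norvegicus as the target, read by paw edema, with stated times of 1 h and 3 h, at a dose of 25 mg/kg by the oral route; a higher number here means more inhibition at the dose given (going by the name of the read-out), a lower number less inhibition. Compound 3 gives the highest number of the three, reaching in this assay 35%. Compound 2 lies lower by more than the usual scatter, and compound 1 lower still, also beyond the scatter. Compound 4, `CC1=C(C(=O)Nc2ccc(F)cc2)C(c2ccc(Cl)cc2)n2c(s/c(=C/c3ccc(F)cc3)c2=O)=N1`, has not yet been measured. It differs from compound 3 in a single place: fluoro in place of bromo on an aromatic carbon. Going by the values given here, no measured pair here shows this exchange, so its effect cannot be read from the data. In this assay a small downward step is expected, close to the edge of the scatter. The expected step is a number 7 percentage points lower from compound 3 to compound 4 (within the scatter). Compound 4 is therefore estimated at 28%, within a range from 12% to 45%.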

Compound 4, a percentage reported as inhibition, in the whole organism at one dose (the size of the read-out at that dose, not a potency): 44%
Estimate against measurement, compound 4: 16 percentage points below; measured number inside the range.
By their numbers in this assay, from the lowest: compounds 1 and 2 (each within the scatter of the next); then compounds 3 and 4 (each within the scatter of the next).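

In this assay, fluoro in place of bromo on this aromatic carbon gives a number 9 percentage points higher from compound 3 to compound 4 (within the scatter). Going by these compounds alone, this is the first exchange in the set made at a single place, and it shows that the two halogens are not told apart at this position, para to a large group, when the rest of the molecule stays the same. No measurement shown here explains this result. On these data alone, it remains open how an amine or a carboxylic acid at this position would read out, and whether the bromo and fluoro groups would still match on a different substitution pattern around the shared core.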